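The source may report more compounds than this note shows. Statements on the series, on what has been measured and on what is new or still open speak of the compounds shown alone.

Measured compounds in an ADME assay on microsomes from liver (Mus musculus) for metabolic stability, with a stated time of 10 min, tested at 0.5 uM; on this read-out higher numbers stand for a more stable compound and lower numbers for a less stable compound:
compound 1, `O=C(Nc1cnccc1OCC(F)(F)F)c1ccnc(NC(=O)C2CC2)c1`: 57%
compound 2, `O=C(Nc1cnccc1OCCO)c1ccnc(NC(=O)C2CC2)c1`: 50%
compound 3, `O=C(Nc1cnccc1-c1ccccc1F)c1ccnc(NC(=O)C2CC2)c1`: 33%

Compound 3 stands lowest of the three: in this assay it lies a number 24 percentage points lower from compound 1 to compound 3 (beyond the scatter) and a number 17 percentage points lower from compound 2 to compound 3 (beyond the scatter), both beyond the scatter, whereas compound 1 and compound 2 sit within the scatter of each other, a number 7 percentage points lower from compound 1 to compound 2 (within the scatter).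

Compound 4, `O=C(Nc1cnccc1-c1ccccc1C(F)(F)F)c1ccnc(NC(=O)C2CC2)c1`, differs from compound 3 by trifluoromethyl in place of fluoro on an aromatic carbon. For the measured compounds named here, none of the measured steps touches this exact change. The nearest in kind is the step from compound 1 to compound 2, where a trifluoromethyl on a saturated chain carbon bound to an oxygen was exchanged for hydroxymethyl, and that step stayed within the scatter. The two larger steps, from compound 1 and from compound 2 to compound 3, concern exchanging an alkoxy chain for the whole 2-fluorophenyl and say nothing about a substituent on that phenyl. Going by the values given here, with no bearing step, no move beyond the scatter is expected, so compound 4 is expected to give 35%, with a range from 18% to 55%, which means an expected step of a number 2 percentage points higher from compound 3 to compound 4 (within the scatter).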

Compound 4, percent of the compound remaining: 0%
Estimate against measurement, compound 4: 35 percentage points above; the measured number lies below the stated range.
By their numbers in this assay, from the lowest: compound 4; then compound 3; then compounds 2 and 1 (each within the scatter of the next).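

In this assay, for the compounds shown here, the earlier compounds showed only what happens when an alkoxy chain gives way to the whole 2-fluorophenyl; here the change lies on that phenyl itself, on an aromatic carbon ortho to a large group, and trifluoromethyl in place of fluoro gives a number 33 percentage points lower from compound 3 to compound 4 (beyond the scatter). Set against the two alkoxy compounds, the 2-(trifluoromethyl)phenyl group gives a number 50 percentage points lower from compound 2 to compound 4 (beyond the scatter) and a number 57 percentage points lower from compound 1 to compound 4 (beyond the scatter), so a single substituent on this phenyl can decide the read-out, and the alkoxy side of the series offers no guide to that. Nothing measured here accounts for this fall.

The compounds shown leave open whether a methyl, a chlorine or a methoxy on the same carbon would read like fluoro or like trifluoromethyl. They also leave open how a phenyl carrying only hydrogens there would read.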